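The source may hold more compounds than are shown below. What is called first, only, known or untested is meant among the compounds shown, and "the series" means these compounds.

Measured so far in a functional assay on HT-29 cells (Homo sapiens) for antiproliferative activity, read by sulforhodamine B assay, with a stated time of 48 h; on this read-out lower numbers stand for stronger inhibition and higher numbers for weaker inhibition: compound 1 `Cc1ccc(NS(=O)(=O)c2ccc(N3CCNC3=O)cc2)cc1` gives 480 nM. Compound 2 `COc1ccc(NS(=O)(=O)c2ccc(N3CCNC3=O)cc2)cc1` gives 800 nM. Compound 3 `Cc1ccccc1NS(=O)(=O)c1ccc(N2CCNC2=O)cc1` gives 200 nM.

Compound 4 `COc1ccccc1NS(=O)(=O)c1ccc(N2CCNC2=O)cc1` has not yet been measured. It arises from compound 3 by one change: methoxy in place of methyl on an aromatic carbon. The same kind of change, (methoxy in place of methyl on an aromatic carbon), has been measured between compound 1 and compound 2, where it gave a 1.7-fold higher number from compound 1 to compound 2 (0.22 log units; within the scatter). The two changes are not the same, since in compound 1 the group sits para to a large group while in compound 3 it sits ortho to a large group. The two cores themselves differ by 2-methylphenyl in place of 4-methylphenyl on a sulfonamide nitrogen, a change that gave a 2.4-fold lower number from compound 1 to compound 3 (0.38 log units; beyond the scatter). Among the compounds with values here, only one measured instance of the change exists, so the expectation rests on that single step of compound 1. For compound 4 the expected step is a 1.7-fold higher number from compound 3 to compound 4 (0.23 log units; within the scatter), in line with the measured one. Compound 4 is therefore estimated at 340 nM, likely between 150 nM and 800 nM.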

Compound 4, half-maximal inhibitory concentration: 550 nM
The estimate for compound 4 lay 1.6-fold (0.21 log units) below the measured number, within the range that was stated.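

Putting 2-methoxyphenyl in place of 2-methylphenyl gives a 2.8-fold higher number from compound 3 to compound 4 (0.44 log units; beyond the scatter), and the two measured instances of the change can now be set side by side: the same change on two cores in this assay, a 1.7-fold higher number (0.22 log units; within the scatter) from compound 1 to compound 2 and a 2.8-fold higher number (0.44 log units; beyond the scatter) from compound 3 to compound 4, 1.7-fold (0.22 log units) apart, within the scatter of two such steps. The two steps cannot be told apart, so in this small set the step from the first core carried over to the second, but two instances make no rule and cannot show whether the larger new step is real. Swapping in 2-methoxyphenyl for 4-methoxyphenyl gives a 1.5-fold lower number from compound 2 to compound 4 (0.16 log units; within the scatter), and swapping it in for 4-methylphenyl gives a 1.1-fold higher number from compound 1 to compound 4 (0.06 log units; within the scatter), so neither swap separates the compounds involved.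

The compounds shown leave open how a chlorine atom, an amine or a longer chain such as ethoxy would fare at this place. They also leave open whether the change behaves alike on any other core.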